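The source may hold more compounds than are shown below. What is called first, only, known or untested is meant among the compounds shown, and "the series" means these compounds.

Measured compounds:
compound 1, `CCn1c(C(=O)N[C@@H](C)C(=O)OC)ccc1C(CC)(CC)c1ccc(OCS(=O)(=O)c2ccccc2)c(C)c1`, > 50000 nM
compound 2, `CCn1c(C(=O)N[C@H](C)C(=O)OC)ccc1C(CC)(CC)c1ccc(OCS(=O)(=O)c2ccccc2)c(C)c1`, > 50000 nM
compound 3, `CCn1c(C(=O)N[C@@H](CC(=O)OC)C(=O)OC)ccc1C(CC)(CC)c1ccc(OCS(=O)(=O)c2ccccc2)c(C)c1`, 6490 nM

In a functional assay on PC-3 cells (Homo sapiens) for antiproliferative activity, read by MTT assay, with a stated time of 24 h (a lower number here means a stronger inhibitor, a higher number a weaker inhibitor), compound 1 gives only a limit of the assay, > 50000 nM, not a number. Compound 2 differs from compound 1 only in the configuration drawn at one stereocentre. In this assay compound 2 also reaches only a limit, > 50000 nM. The step that the two limits leave unreadable from compound 1 to compound 2 therefore cannot be read because of the limit of > 50000 nM in this assay, at which 2 of the 3 values shown sit. Going by the values given here, compound 3 is the one measured compound with a number, and the step of an at least 7.7-fold lower number from compound 1 to compound 3 (0.88 log units; beyond the scatter) shows that methoxycarbonyl in place of hydrogen on the saturated chain carbon made a readable difference.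

Compound 4, `CCn1c(C(=O)NCCCO)ccc1C(CC)(CC)c1ccc(OCS(=O)(=O)c2ccccc2)c(C)c1`, is not yet measured. It differs from compound 1 by 3-hydroxypropyl in place of 1-(methoxycarbonyl)ethyl on an amide-type nitrogen. Among the compounds with values here, no measured step touches this change: the only readable step, from compound 1 to compound 3, adds a methoxycarbonyl, whereas here the 1-(methoxycarbonyl)ethyl group is removed and a 3-hydroxypropyl group enters. With compound 1 sitting at a limit, the step in this assay can only be guessed; a small shift, or none beyond the scatter, is expected, and the expected step is an at least 1.2-fold lower number from compound 1 to compound 4 (0.09 log units; that floor lies within the scatter). Compound 4 is estimated at 40000 nM, with a range from 8000 nM to 150000 nM.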

Compound 4, half-maximal inhibitory concentration: 11300 nM
For compound 4 the middle estimate is 3.5-fold (0.55 log units) above the measured one; the range from low to high includes it.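

In this assay the 1-(methoxycarbonyl)ethyl group on the amide-type nitrogen proves not to be required for a readable number: replacing it with 3-hydroxypropyl gives an at least 4.4-fold lower number from compound 1 to compound 4 (0.64 log units; beyond the scatter) and, from the other drawn configuration, an at least 4.4-fold lower number from compound 2 to compound 4 (0.64 log units; beyond the scatter) as well. The second readable number at this nitrogen also changes the picture, since a 1.7-fold higher number from compound 3 to compound 4 (0.24 log units; within the scatter) places compound 4, which has no methoxycarbonyl and no defined stereocentre in this chain, level with compound 3, which has a 1,2-bis(methoxycarbonyl)ethyl group there. As far as these compounds go, the true size of the two steps from compounds 1 and 2 stays unknown, and each is only a floor, because both starting values are limits and not numbers: the limit of > 50000 nM in this assay, at which 2 of the 4 values shown sit.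

The compounds shown do not separate the effect of the hydroxyl end of the new chain from that of losing the 1-(methoxycarbonyl)ethyl group, and a plain propyl chain would be needed to tell these apart. From the compounds shown here alone, how a chain ending in an amine or a carboxylic acid, or a longer chain ending in a hydroxyl, would read at this nitrogen also remains open.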